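Chloro in place of fluoro on the fused ring

This account rests on a few compounds, and the source may have more. Where it says the series, first, only, none or still open, it means among the compounds named here.

Compound 2 `CS(=O)(=O)c1ccc(Nc2nccc(Nc3nc4ccc(F)cc4s3)n2)cc1`: 560 nM
Compound 1 `CS(=O)(=O)c1ccc(Nc2ncc(F)c(Nc3nc4ccccc4s3)n2)cc1`: 3170 nM
Compound 3 `Cc1cnc(Nc2ccc(S(C)(=O)=O)cc2)nc1Nc1nc2ccc(F)cc2s1`: > 50000 nM, a limit of the assay rather than a number

In a functional assay on HeLa cells (Homo sapiens) for antiproliferative activity, read by MTT assay, with a stated time of 48 h (a higher number here means a weaker inhibitor, a lower number a stronger inhibitor), compound 2 gives the lowest of the two numbers measured; compound 1 stands above it, and the two differ in more than one place, so their values are reported side by side without a step between them. Compound 4 `CS(=O)(=O)c1ccc(Nc2nccc(Nc3nc4ccc(Cl)cc4s3)n2)cc1` is not yet measured. It carries chloro in place of fluoro on an aromatic carbon. Within the data shown here, the single measured step, an at least 89-fold higher number from compound 2 to compound 3 (1.95 log units; beyond the scatter), concerns a methyl on the core and not the fused ring, so it does not bear on this change. Among the measured compounds shown here, no measured step in this set reaches the place of the halogen. Compound 4 is therefore expected to show a 1.1-fold lower number from compound 2 to compound 4 (0.05 log units; within the scatter), a change that stays within the scatter. Compound 4 is estimated at 500 nM, with a range from 150 nM to 2000 nM in this assay.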

Compound 4, half-maximal inhibitory concentration: 1400 nM
Compound 4: the middle estimate sits 2.8-fold (0.45 log units) below what was measured; the range from low to high includes it.
By their numbers in this assay, from the lowest: compound 2; then compound 4; then compound 1. At a limit, above all of these: compound 3.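

In this assay the halogen on the fused ring proves not to be interchangeable: chloro in place of fluoro gives a 2.5-fold higher number from compound 2 to compound 4 (0.40 log units; beyond the scatter) and so a modest loss that lies beyond the scatter. Among these compounds, this is the first measured step at the fused ring, as the only earlier step lay on the shared core, and it shows that this position responds to a single exchange of one halogen for another, with fluoro giving the lower number of the pair. Nothing measured here accounts for why the two halogens differ.

As far as these compounds go, only these two halogens can be compared at this place, so whether a methoxy, an amine or a carboxylic acid there would lower or raise the number remains open. From the compounds shown here alone, it also remains open whether the same exchange would have a similar effect on a core that carries a further substituent.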